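A few compounds are considered here, and "the series" means these few. Any claim that something is new, unique, unknown or untested is made for them only; others in the source may bear on it.

Measured in an assay for inhibition of Fatty-acid amide hydrolase 1 (Rattus norvegicus), using a Dixon plot; on this read-out higher numbers stand for weaker inhibition and lower numbers for stronger inhibition:
compound 1 `O=Cc1ccc(-c2cnc(C(=O)CCCCCCc3ccccc3)o2)nc1` — 2.2 nM
compound 2 `CSC(=O)CCCCc1cnc(C(=O)CCCCCCc2ccccc2)o1` — 1.8 nM
compound 3 `O=CCCCCc1cnc(C(=O)CCCCCCc2ccccc2)o1` — 14.6 nM

Among these three numbers compound 1 stands second highest; the nearest neighbour is a 1.2-fold lower number from compound 1 to compound 2 (0.09 log units; within the scatter), the furthest is a 6.6-fold higher number from compound 1 to compound 3 (0.82 log units; beyond the scatter). Compound 4 `CSCCCCCc1cnc(C(=O)CCCCCCc2ccccc2)o1` differs from compound 1 by a group of 7 heavy atoms (6 carbon, 1 sulfur; no ring) in place of a group of 8 heavy atoms (6 carbon, 1 nitrogen, 1 oxygen; one six-membered aromatic ring with 1 hetero atom), on an aromatic carbon. Both measured steps from compound 1 bear on this, since each likewise put a group with no ring on that aromatic carbon: one stayed within the scatter, the other rose modestly. The chain entering compound 4 carries no carbonyl and so resembles compound 3 more than compound 2, hence a modest rise is expected, a 3.6-fold higher number from compound 1 to compound 4 (0.56 log units; beyond the scatter). Compound 4 is therefore estimated at 8 nM, with a range from 2.5 nM to 25 nM.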

Compound 4, inhibition constant: 8.1 nM
Beside the measured number, compound 4's estimate is 1.0-fold (0.01 log units) below it; the measured number falls inside the stated range.
By their numbers in this assay, from the lowest: compounds 2 and 1 (each within the scatter of the next); then compounds 4 and 3 (each within the scatter of the next).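

In this assay, the 5-(methylsulfanyl)pentyl chain on this aromatic carbon does not match the ring-bearing group it replaces (a 3.7-fold higher number from compound 1 to compound 4 (0.57 log units; beyond the scatter)). Keeping the methylsulfanyl end while losing the carbonyl also gives a clear step (a 4.5-fold higher number from compound 2 to compound 4 (0.65 log units; beyond the scatter)), whereas exchanging the formyl end for (methylsulfanyl)methyl stays within the scatter (a 1.8-fold lower number from compound 3 to compound 4 (0.26 log units; within the scatter)), so the sulfur alone does not reproduce the result of the intact (methylsulfanyl)carbonyl end. No available evidence explains these steps. From the compounds shown here alone, whether a carboxylic acid, an amide or a longer chain at this position would do as well remains open.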